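The source may hold more compounds than are shown below. What is called first, only, known or untested is meant among the compounds shown, and "the series" means these compounds.

In a functional assay on HL-60 cells (Homo sapiens) for antiproliferative activity (on this read-out lower numbers stand for stronger inhibition and higher numbers for weaker inhibition), compound 3 (`CCOC(=O)c1ccc(Oc2ccc(N(C)C)cc2)cc1O`) stands at > 30000 nM, which is a limit of the assay and not a number. Its two relatives are also known only by limits. Compound 1 (`CCOC(=O)c1ccc(Oc2ccc(N(C)C)cc2)cc1`) gives > 20000 nM, a limit. Compound 2 (`CCOC(=O)c1ccc(Oc2ccc(OC)cc2)cc1`) gives > 20000 nM, also a limit.

The next compound, compound 4 (`CCOC(=O)c1ccc(Oc2ccc(OC)cc2)cc1O`), differs from compound 3 in one place: methoxy in place of dimethylamino on an aromatic carbon. In plain terms, this puts methoxy in place of dimethylamino on an aromatic carbon, para to a large group.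

For the measured compounds named here, two measured steps bear on this change. The same exchange, made without the hydroxy group, is a step that the two limits leave unreadable from compound 1 to compound 2. The addition of hydroxy in place of hydrogen on an aromatic carbon is a step that the two limits leave unreadable from compound 1 to compound 3. Neither step has a readable size, so neither gives a direction or a measured effect to carry over. With no number yet seen in this series, no step beyond the usual scatter is expected, and a further limit is the likeliest report.

The estimated change is a number no higher from compound 3 to compound 4 (the limit leaves the size open). For compound 4 the expected value is 30000 nM, with an estimated range from 15000 nM to 60000 nM.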

Compound 4, half-maximal inhibitory concentration: > 30000 nM
Compound 4 was reported as a limit; the forecaster's own chance of this, stated with the estimate: 85%; the middle value sits exactly at the limit.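

In this assay compound 4 gives > 30000 nM, which is a limit of the assay and not a number. Its steps from compound 3 and from compound 2 therefore cannot be read. From the compounds shown here alone, with all four compounds known only by limits, it stays open whether swapping dimethylamino for methoxy or adding hydroxy changes the activity at all.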